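Methoxy to chloro on the side-chain aryl ring

The source may report more compounds than this note shows. Statements on the series, on what has been measured and on what is new or still open speak of the compounds shown alone.

The series shares one core, shown with compound 1 `COc1cccc([C@@H](CO)O[C@H]2CCCN(Cc3ccc(C(=O)O)cc3C)[C@H]2c2ccccc2)c1`, and is compared in an assay on isolated protein for activation of cGMP-dependent protein kinase 1 (Homo sapiens), read by ADP-Glo, with stated times of 30 min and 2 h; a higher number here means that more compound is needed for the effect, a lower number that less compound is needed. Compound 1 reaches only the limit of this assay, giving > 200000 nM. Compound 2 `CC(=O)NS(=O)(=O)c1ccc(CN2CCC[C@H](O[C@H](CO)c3cc(Cl)cc(Cl)c3)[C@@H]2c2ccccc2)cc1` likewise sits at the limit, giving > 200000 nM in this assay. Among the compounds with values here, compound 3 `COC(=O)Nc1cc(C(=O)O)ccc1CN1CCC[C@H](O[C@H](CO)c2cc(Cl)cc(Cl)c2)[C@@H]1c1ccccc1` is the one member with a number, giving 69000 nM in this assay. Two of the three values rest at the limit of > 200000 nM in this assay, at which 2 of the 3 values shown sit, so compound 1 stands at the top of the range covered here and cannot be ordered against compound 2, while compound 3 alone needs less compound than that limit.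

Compound 4 `Cc1cc(C(=O)O)ccc1CN1CCC[C@H](O[C@H](CO)c2cccc(Cl)c2)[C@@H]1c1ccccc1` has not been measured in this assay. It differs from compound 1 in one place: chloro in place of methoxy on an aromatic carbon, so that the 3-methoxyphenyl becomes a 3-chlorophenyl. Within the data shown here, no measured pair isolates this change. Because compound 3 with two chloro groups on that ring gives 69000 nM in this assay, a modest step toward less compound is expected, an at least 1.3-fold lower number from compound 1 to compound 4 (0.12 log units; that floor lies within the scatter). Compound 4 is accordingly estimated at 150000 nM, with a range from 40000 nM to 600000 nM, and a fair chance remains that this assay again reports only a limit.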

Compound 4, half-maximal effective concentration: 93000 nM
The estimate for compound 4 lay 1.6-fold (0.21 log units) above the measured number, within the range that was stated.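

In this assay, within the data shown here, replacing methoxy with chloro on this aromatic carbon gives an at least 2.1-fold lower number from compound 1 to compound 4 (0.33 log units; beyond the scatter), the first reading of a single change at this position. The step lies beyond the scatter, so the position does respond to the change from 3-methoxyphenyl to 3-chlorophenyl, although compound 4 still gives only 93000 nM. Compound 1 stands at a limit of the assay, so the step is a floor and its full size remains unknown: the limit of > 200000 nM in this assay, at which 2 of the 4 values shown sit.

On these data alone, it remains open whether the gain comes from the entry of chloro or simply from the loss of methoxy, and a plain hydrogen, a fluoro or a methyl on the same carbon would help to separate the two. The part played by the second chloro group in compound 3 also stays unresolved, as that compound differs from compound 4 in more than one place, and a compound carrying the second chloro group with all else as in compound 4 would isolate it.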